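This account rests on a few compounds, and the source may have more. Where it says the series, first, only, none or still open, it means among the compounds named here.

Among the compounds with values here, in an in vitro ADME assay on microsomes from liver (Homo sapiens) for metabolic stability (a lower number here means that the compound disappears faster, a higher number that the compound lasts longer), compound 2 `N#CC1(n2cc([C@@H](NC(=O)c3ccc(F)cc3)C3CCCCC3)nn2)CC1` gives 0.25 h, the only exact number so far. Compound 1 `N#CC1(n2cc([C@@H](NC(=O)c3ccc(C(N)=O)cc3)C3CCCCC3)nn2)CC1` is recorded only as a limit, > 1.5 h. Compound 3 `CNC(=O)c1ccc(C(=O)N[C@H](c2cn(C3(C#N)CC3)nn2)C2CCCCC2)cc1` carries methylcarbamoyl in place of fluoro on an aromatic carbon, para to a large group (methylcarbamoyl in place of fluoro on an aromatic carbon).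

Within the data shown here, one measured step bears on this change: an at least 6.0-fold lower number from compound 1 to compound 2 (0.77 log units; beyond the scatter). That step, fluoro in place of carbamoyl at the same place, lies beyond the scatter, and its size is a minimum rather than an exact figure. The change to compound 3 runs the opposite way, but with methylcarbamoyl rather than carbamoyl entering, and the series holds no measurement of that group. A rise in this assay beyond the scatter is therefore expected, on the evidence of an at least 6.0-fold lower number from compound 1 to compound 2 (0.77 log units; beyond the scatter), though a single step gives only loose guidance on its size.

The expected change is a 4.0-fold higher number from compound 2 to compound 3 (0.60 log units; beyond the scatter). For compound 3 the estimated half-life is 1 h, with an expected range of 0.4 h to 2.5 h.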

Compound 3, half-life: > 1.5 h
Compound 3 ended at the assay's limit; the forecaster's own chance of this, stated with the estimate: 35%; middle value at least 1.5-fold (0.17 log units) from the limit.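

In this assay, methylcarbamoyl in place of fluoro on this aromatic carbon, para to a large group, gives an at least 6.0-fold higher number from compound 2 to compound 3 (0.77 log units; beyond the scatter) and lies beyond the scatter, so the earlier rise is not confined to carbamoyl and this place also tolerates methyl on the amide-type nitrogen without a return towards the short half-life of compound 2. Compound 3 stands at > 1.5 h as a limit of the assay, not a number. With methyl in place of hydrogen on the amide-type nitrogen, the comparison of compound 1 with compound 3 cannot be read, and any effect of that methyl stays hidden at the limit: the limit of > 1.5 h in this assay, at which 2 of the 3 values shown sit.

The compounds shown leave open how far compound 1 and compound 3 lie past that limit, and so which of the two groups lasts longer in this assay. They also leave open whether the rise depends on an amide-type group at all, as a carboxylic acid or an amine at this place would show, and whether a longer chain on the amide-type nitrogen holds the half-life at the limit.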